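The source may hold more compounds than are shown below. What is called first, only, known or untested is meant among the compounds shown, and "the series" means these compounds.

Compound 1 `CN1CCN(CC#Cc2cc3ncnc(Nc4ccc(OCc5cccc(F)c5)c(Cl)c4)c3s2)CC1` carries a 4-methylpiperazin-1-yl group on a saturated chain carbon bound to a triple-bonded carbon. For the measured compounds named here, in an ADME assay on HepG2 cells (Homo sapiens) for cytotoxicity (on this read-out lower numbers stand for higher toxicity in this test and higher numbers for lower toxicity in this test), compound 1 gives 11 uM, the middle of the three numbers measured so far. With dipropylamino at that place, compound 2 `CCCN(CC#Cc1cc2ncnc(Nc3ccc(OCc4cccc(F)c4)c(Cl)c3)c2s1)CCC` gives 26.5 uM, and with pyrrolidin-1-yl, compound 3 `Fc1cccc(COc2ccc(Nc3ncnc4cc(C#CCN5CCCC5)sc34)cc2Cl)c1` gives 4.9 uM.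

Compound 4 `CC(C)(C)OC(=O)N1CCN(CC#Cc2cc3ncnc(Nc4ccc(OCc5cccc(F)c5)c(Cl)c4)c3s2)CC1` has not yet been measured. It keeps the piperazine ring of compound 1 and changes one group: tert-butoxycarbonyl in place of methyl on an amine nitrogen in a ring. Here tert-butoxycarbonyl stands in place of methyl on an amine nitrogen in a ring.

Going by the values given here, no measured step alters that nitrogen alone, so the evidence is indirect. The closest guides are swaps of the whole amine group: a 2.4-fold higher number from compound 1 to compound 2 (0.38 log units; beyond the scatter), a 2.2-fold lower number from compound 1 to compound 3 (0.35 log units; beyond the scatter) and a 5.4-fold lower number from compound 2 to compound 3 (0.73 log units; beyond the scatter). These modest steps run in both directions, so they show that this assay responds to changes in this group but give no clear direction for compound 4. A step beyond the scatter is therefore not expected, though the largest of these steps keeps the range wide. The expected change is small: a 1.4-fold higher number from compound 1 to compound 4 (0.13 log units; within the scatter). For compound 4 the estimated value is 15 uM, with an expected range from 5.5 uM to 40 uM.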

Compound 4, half-maximal toxic concentration: > 24 uM
Compound 4: only a limit was reported (the forecaster's own chance of this, stated with the estimate: 12%); at least 1.6-fold (0.20 log units) between middle value and limit.
By their numbers in this assay, from the lowest: compound 3; then compound 1; then compound 2.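

Swapping methyl for tert-butoxycarbonyl on the ring nitrogen gives, in this assay, an at least 2.1-fold higher number from compound 1 to compound 4 (0.33 log units; beyond the scatter). For the compounds shown here, the earlier steps each replaced the whole amine group, so this is the first evidence that a change at this one nitrogen, with the piperazine ring kept, can shift the read-out beyond the scatter, here towards lower toxicity in this test. Compound 4 is reported only as a limit, > 24 uM, so the step has a floor but no known ceiling: the limit of > 24 uM in this assay, at which 1 of the 4 values shown sits.

The compounds shown carry only methyl and tert-butoxycarbonyl on this nitrogen, which leaves open whether the shift follows from the carbonyl, from the tert-butyl part or only from the two together. A hydrogen, an acetyl group or a longer alkyl chain on the same nitrogen would help to separate these possibilities and show how far the read-out in this assay can move at this position.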